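Notes on solubility across compounds 1 to 4

The source may hold more compounds than are shown below. What is called first, only, known or untested is meant among the compounds shown, and "the series" means these compounds.

Within the data shown here, compound 1 `Cc1cc(C#N)cc(C)c1Oc1ccnc(NCCn2ccc(=O)[nH]c2=O)n1` is the only member of the set with a number in a physicochemical assay for solubility, read by HPLC, in phosphate buffer, with a stated time of 2 h, at pH 7.4; a lower number here means a less soluble compound, a higher number a more soluble compound: compound 1 gives 62.9 ug/mL. For compound 3 `Cc1cc(/C=C/C#N)cc(C)c1Oc1ccnc(NCCn2ccc(=O)[nH]c2=O)n1`, this assay returns only a limit, < 1 ug/mL, so compound 3 stands at the less soluble end of what has been seen. Compound 2 `Cc1cc(/C=C/C#N)cc(C)c1Oc1nc(NCCn2ccc(=O)[nH]c2=O)ncc1Cl` likewise returns only a limit, < 0.1 ug/mL. Among the measured compounds shown here, the step of an at least 62-fold lower number from compound 1 to compound 3 (1.79 log units; beyond the scatter) is the one readable change in the set, while the step that the two limits leave unreadable from compound 2 to compound 3 is hidden by the two limits the limit of < 0.1 ug/mL in this assay, at which 1 of the 3 values shown sits, and (the limit of < 1 ug/mL in this assay, at which 1 of the 3 values shown sits).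

Compound 4 `Cc1cc(/C=C/C#N)cc(C)c1Oc1cc(N)nc(NCCn2ccc(=O)[nH]c2=O)n1` differs from compound 3 by amino in place of hydrogen on an aromatic carbon. For the measured compounds named here, neither measured step involves an amino group or this position, so no measured step bears on the change, and the data give no size to expect in this assay in either direction. Compound 4 is therefore expected to sit close to the limit shown by compound 3, with the expected step of a number no lower from compound 3 to compound 4 (the limit leaves the size open) carrying wide uncertainty. The estimate for compound 4 is 1 ug/mL, within 0.2 ug/mL to 5 ug/mL.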

Compound 4, solubility: 0.43 ug/mL
For compound 4 the middle estimate is 2.3-fold (0.37 log units) above the measured one, and the stated range covers the measured number.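

In this assay, among these compounds, compound 3 returns only a limit, < 1 ug/mL, so no step to compound 4 can be read. From the compounds shown here alone, whether amino in place of hydrogen on an aromatic carbon raises or lowers the number in this assay, and by how much, stays open.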